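A Halogen Swap at the End of the Chain

A few compounds are considered here, and "the series" means these few. Any claim that something is new, unique, unknown or untested is made for them only; others in the source may bear on it.

In a functional assay on PC-3 cells (Homo sapiens), read by fluorescence and BrdU incorporation, with a stated time of 48 h, tested at 25 uM (on this read-out higher numbers stand for a weaker effect at the one concentration tested and lower numbers for a stronger effect), compound 2 `COc1cc(OC)c(C(=O)/C=C/c2ccc(F)cc2)c(OC)c1` gives 0.4%, and compound 1 `COc1cccc(/C=C/C(=O)c2c(OC)cc(OC)cc2OC)c1` gives 0.9%; the step of a number 0.5 percentage points lower from compound 1 to compound 2 (within the scatter) lies within the scatter, so the two sit together at the strong end of this read-out. Compound 3 `COc1cc(OC)c(C(=O)/C=C/c2ccc(Br)cc2)c(OC)c1` carries the change (bromo in place of fluoro on an aromatic carbon), on an aromatic carbon para to a large group. Within the data shown here, only the step from compound 1 to compound 2 bears on this change, and it was within the scatter, so no step beyond the scatter is expected, a number 0.6 percentage points higher from compound 2 to compound 3 (within the scatter). Compound 3 is therefore estimated at 1%, in a range from 0% to 8%.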

Compound 3, a percentage reported as activity, at one concentration (the size of the read-out at that concentration, not a potency): 0.4%
For compound 3 the middle estimate is 0.6 percentage points above the measured one; measured number inside the range.
By their numbers in this assay, from the lowest: compounds 2, 3 and 1 (each within the scatter of the next).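

In this assay, bromo in place of fluoro on an aromatic carbon para to a large group gives no change at the digits printed from compound 2 to compound 3 (within the scatter), so this position takes either halogen with no step beyond the scatter. The wider swap to 4-bromophenyl from 3-methoxyphenyl gives a number 0.5 percentage points lower from compound 1 to compound 3 (within the scatter), which leaves all three compounds together at the strong end of the read-out. No measurement at hand offers an explanation for this. From the compounds shown here alone, whether an amine or a carboxylic acid on this carbon would keep the read-out there remains open, as does whether the two halogens would separate at a lower concentration.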